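The source may report more compounds than this note shows. Statements on the series, on what has been measured and on what is new or still open speak of the compounds shown alone.

Compound 1 `C=CCC1C(=C)C(=O)N(c2ccccc2)N1c1ccccc1` was tested in a functional assay on MCF7 cells (Homo sapiens) for inhibition, read by MTT assay, with a stated time of 48 h (a lower number here means a stronger inhibitor, a higher number a weaker inhibitor), where compound 1 gives 5100 nM, the lower of the two numbers recorded so far. Compound 2 `C=C1CN(C)N(c2ccccc2)C1=O` sits well above it; in this assay compound 2 gives 56000 nM, a gap beyond the usual scatter. Compound 3 `C=C1C(=O)N(c2ccccc2)N(c2ccccc2)C1CC` differs from compound 1 by a single change: methyl in place of vinyl on a saturated chain carbon bound to a saturated ring carbon. Among the measured compounds shown here, no measured pair shows the effect of this change, so compound 3 is expected to stay close to compound 1, with the step of a 1.2-fold higher number from compound 1 to compound 3 (0.07 log units; within the scatter) not expected to exceed the scatter. Compound 3 is therefore estimated at 6000 nM, within the range 2500 nM to 15000 nM.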

Compound 3, half-maximal inhibitory concentration: 20000 nM
The estimate for compound 3 lay 3.3-fold (0.52 log units) below the measured number, outside the stated range (above it).
By their numbers in this assay, from the lowest: compound 1; then compound 3; then compound 2.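

Methyl in place of vinyl on a saturated chain carbon bound to a saturated ring carbon gives in this assay a 3.9-fold higher number from compound 1 to compound 3 (0.59 log units; beyond the scatter), so this position responds to the chain it carries. Cut one bond further out, the change reads allyl to ethyl, and the shorter ethyl chain goes with the weaker inhibitor. Nothing available accounts for this step.

The change removes both the double bond and a chain carbon, and the compounds shown do not separate the two. As far as these compounds go, a saturated propyl chain here would tell them apart, while a longer chain or an amine remains open.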